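The source may hold more compounds than are shown below. What is called first, only, known or untested is meant among the compounds shown, and "the series" means these compounds.

Measured compounds in an ADME assay on the whole organism (Macaca fascicularis) for pharmacokinetics, at a dose of 1 mg/kg by the oral route; on this read-out lower numbers stand for lower exposure and higher numbers for higher exposure at the dose given:
compound 1 `Cc1sc(N(CC2CC2)[C@H](C)c2ccc(-c3cc(Cl)ccc3-c3nc(=O)o[nH]3)cc2)nc1C(=O)NS(C)(=O)=O` gives 726 ng.h/mL;
compound 2 `Cc1sc(N(CC2CC2)[C@H](C)c2ccc(-c3cc(Cl)ccc3-c3nc(=O)o[nH]3)cc2)nc1C(=O)NS(=O)(=O)C1CC1` gives 3740 ng.h/mL;
compound 3 `Cc1ccc(-c2nc(=O)s[nH]2)c(-c2ccc([C@@H](C)N(CC3CC3)c3nc(C(=O)NS(=O)(=O)C4CC4)c(C4CC4)s3)cc2)c1` gives 39800 ng.h/mL.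

Compound 3 stands highest of the three numbers in this assay, with compound 2 nearest and compound 1 furthest, both gaps beyond the scatter. Compound 4 `CONC(=O)c1ccc(C)cc1-c1ccc([C@@H](C)N(CC2CC2)c2nc(C(=O)NS(=O)(=O)C3CC3)c(C3CC3)s2)cc1` differs from compound 3 by a group of 5 heavy atoms (2 carbon, 1 nitrogen, 2 oxygen; no ring) in place of a group of 6 heavy atoms (2 carbon, 2 nitrogen, 1 oxygen, 1 sulfur; one five-membered aromatic ring with 3 hetero atoms), on an aromatic carbon, on an aromatic carbon of a six-membered aromatic ring of carbon only, ortho to a large group and para to a methyl group. Going by the values given here, the only measured step, a 5.2-fold higher number from compound 1 to compound 2 (0.71 log units; beyond the scatter), concerns the group on the sulfonyl sulfur and does not bear on this exchange; no measured pair shows what replacing the five-membered aromatic ring does in this assay. The direction of the step from compound 3 is therefore open, and a wide range is appropriate. Compound 4 is estimated at 20000 ng.h/mL, range 4000 ng.h/mL to 80000 ng.h/mL, an expected step of a 2.0-fold lower number from compound 3 to compound 4 (0.30 log units; within the scatter).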

Compound 4, area under the concentration-time curve: 24000 ng.h/mL
Compound 4: middle estimate off by 1.2-fold (0.08 log units), on the low side, and the stated range covers the measured number.
By their numbers in this assay, from the lowest: compound 1; then compound 2; then compounds 4 and 3 (each within the scatter of the next).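

In this assay, methoxycarbamoyl in place of the five-membered aromatic ring, on the aromatic carbon ortho to a large group, gives a 1.7-fold lower number from compound 3 to compound 4 (0.22 log units; within the scatter). This position therefore takes a group with no ring without a step beyond the scatter, so the ring is not required for exposure of this size in this pair; the earlier step spoke only to the group on the sulfonyl sulfur. Nothing measured here bears on why the number holds.

Going by these compounds, what a carboxylic acid or an amine at this aromatic carbon would give stays open, as does whether the same exchange reads alike on the core of compound 2.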